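The source may report more compounds than this note shows. Statements on the series, on what has been measured and on what is new or still open speak of the compounds shown alone.

Measured in a functional assay on HeLa cells (Homo sapiens) for antiproliferative activity, read by MTT assay, with a stated time of 48 h; on this read-out lower numbers stand for stronger inhibition and higher numbers for weaker inhibition:
- compound 1 `COc1ccc(C(=O)c2ccc(OC)c3c2OC(C)(C)C=C3)c(NC(=O)CN(C)C)c1`: 1050 nM
- compound 2 `C=C(c1ccc(OC)cc1NC(=O)CN)c1ccc(OC)c2c1C=CC(C)(C)O2`: 200 nM

Of these two, compound 2 has the lower number, at 200 nM, and compound 1 is its nearest neighbour. Compound 3 `C=C(c1ccc(OC)cc1NC(=O)CNCC)c1ccc(OC)c2c1C=CC(C)(C)O2` departs from compound 2 in one place: ethyl in place of hydrogen on an amine nitrogen. Within the data shown here, no measured pair isolates this change, since compound 1 and compound 2 differ in more than one place. In this assay, little or no shift beyond the scatter is expected, with any shift leaning towards weaker inhibition. The expected change is a 1.5-fold higher number from compound 2 to compound 3 (0.18 log units; within the scatter). The estimated value for compound 3 is 300 nM, within an expected range of 100 nM to 900 nM.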

Compound 3, half-maximal inhibitory concentration: 2590 nM
Estimate against measurement, compound 3: 8.6-fold (0.94 log units) below; the whole stated range lies below it.
By their numbers in this assay, from the lowest: compound 2; then compound 1; then compound 3.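

In this assay ethyl in place of hydrogen on the amine nitrogen gives a 13-fold higher number from compound 2 to compound 3 (1.11 log units; beyond the scatter) and so marks this nitrogen as a place where the change matters. The earlier compounds shown here could not show this, since compound 1 and compound 2 differ in more than one place. Nothing available explains the loss of activity. Still open, on these data alone, is how a single methyl or a longer chain such as propyl on this nitrogen would compare with hydrogen and ethyl. As far as these compounds go, a ring amine such as pyrrolidine at this position is equally open.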